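Shortening the butyl chain on the shared core

A few compounds are considered here, and "the series" means these few. Any claim that something is new, unique, unknown or untested is made for them only; others in the source may bear on it.

Going by the values given here, compound 2 `CCCCc1ccnc(C(=O)Nc2nn[nH]n2)c1` is the weaker of the two compounds measured so far: in a functional assay on the whole organism for inhibition, with Rattus norvegicus as the target, at a dose of 3 mg/kg by the oral route (a higher number here means a stronger effect of the compound at the dose given, a lower number a weaker effect), compound 2 gives 33%, while compound 1 `O=C(Nc1nn[nH]n1)c1cc(Cl)ccn1` gives 72%. Among the compounds with values here, the single measured step joining them, a number 39 percentage points lower from compound 1 to compound 2 (beyond the scatter), is the only comparison available, and it is well beyond the scatter.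

Compound 3 `Cc1ccnc(C(=O)Nc2nn[nH]n2)c1` differs from compound 2 by hydrogen in place of propyl on a saturated chain carbon bound to an aromatic carbon. This removes most of the chain whose introduction in place of chloro went with the large fall from compound 1 to compound 2. The step from compound 1 to compound 2 therefore bears directly on the change to compound 3, though in the opposite sense: the butyl chain is cut back to methyl, not to chloro, so a full return to the level of compound 1 is not assumed. A rise beyond the scatter in this assay is expected, of size a number 22 percentage points higher from compound 2 to compound 3 (beyond the scatter), because compound 2 sits at 33% below compound 1.

The estimate for compound 3 in this assay is 55%, expected to fall between 35% and 75%.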

Compound 3, a percentage reported as inhibition, in the whole organism at one dose (the size of the read-out at that dose, not a potency): 42%
For compound 3 the middle estimate is 13 percentage points above the measured one, within the range that was stated.
By their numbers in this assay, from the lowest: compounds 2 and 3 (each within the scatter of the next); then compound 1.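

In this assay the read-out is a number 9 percentage points higher from compound 2 to compound 3 (within the scatter) when butyl is cut back to methyl, so across this span the chain length makes no difference that can be told from the scatter. With methyl in place of chloro on the same aromatic carbon, the read-out is a number 30 percentage points lower from compound 1 to compound 3 (beyond the scatter) and, taken with the earlier butyl step, this shows that the loss from compound 1 does not require a long chain: among the three compounds, the high read-out stays with chloro alone. No measurement is at hand that explains why chloro stands apart from these two alkyl groups.

Still open, from the compounds shown here alone, is whether the higher read-out of compound 1 is particular to chloro or is shared by other groups on this aromatic carbon, such as fluoro, bromo, methoxy or an amine, and where plain hydrogen would fall. Each read-out comes from a single oral dose, so these compounds also leave open whether the differences would hold at other doses.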